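Selenium to sulfur on a shared core, before the measurement

This account rests on a few compounds, and the source may have more. Where it says the series, first, only, none or still open, it means among the compounds named here.

Compound 1 `C[Se]/C(=N\C(=O)c1cc2ccccc2s1)NC(=O)c1cc2ccccc2s1`: 34700 nM
Compound 2 `CS/C(=N\C(=O)c1ccno1)NC(=O)c1ccno1`: reaches only a limit of the assay, > 100000 nM
Compound 3 `C[Se]/C(=N\C(=O)c1ccco1)NC(=O)c1ccco1`: 40200 nM

In an ADME assay on MCF-10A cells (Homo sapiens) for cytotoxicity, read by MTT assay, with a stated time of 72 h (on this read-out higher numbers stand for weaker inhibition of growth and lower numbers for stronger inhibition of growth), compound 3 gives the higher of the two numbers actually obtained, but compound 1 sits so close that the gap lies within the usual scatter, and the two cannot be ranked against each other. Compound 2 stands apart, at the limit described in the limit of > 100000 nM in this assay, at which 1 of the 3 values shown sits, and so contributes no number to compare.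

Compound 4 `CS/C(=N\C(=O)c1ccco1)NC(=O)c1ccco1` differs from compound 3 by a group of 2 heavy atoms (1 carbon, 1 sulfur; no ring) in place of a group of 2 heavy atoms (1 carbon, 1 selenium; no ring), on a carbon with a double bond to nitrogen, in words a group of 2 heavy atoms (1 carbon, 1 sulfur; no ring) in place of a group of 2 heavy atoms (1 carbon, 1 selenium; no ring), on a carbon with a double bond to nitrogen. Among the measured compounds shown here, no pair of measured compounds covers this exchange on the same core, so its size has not been tested here. Compound 2 carries the methylsulfanyl group, yet on a different core, so it offers no direct comparison.

Compound 4 is expected to come out somewhat weaker, a step of a 1.7-fold higher number from compound 3 to compound 4 (0.24 log units; within the scatter), with an estimated value of 70000 nM between 30000 nM and 160000 nM.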

Compound 4, concentration for total growth inhibition: 46500 nM
Beside the measured number, compound 4's estimate is 1.5-fold (0.18 log units) above it; the measured number falls inside the stated range.
By their numbers in this assay, from the lowest: compounds 1, 3 and 4 (each within the scatter of the next). At a limit, above all of these: compound 2.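

Among the compounds shown here, this pair gives the first direct reading of the exchange of the selenium-bearing group for methylsulfanyl on a shared core, on a carbon with a double bond to nitrogen. In this assay, the exchange gives a 1.2-fold higher number from compound 3 to compound 4 (0.06 log units; within the scatter), so on this core the two groups cannot be told apart, and selenium is not required for a number of this size. No measured property shown here bears on this result.

From the compounds shown here alone, whether the same exchange is equally small on the core of compound 1 stays open, as that core appears here only with selenium. Also open, going by these compounds, is what an amine or a longer chain, such as ethylsulfanyl, would do in place of methylsulfanyl at this carbon.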